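The source may hold more compounds than are shown below. What is called first, only, known or untested is meant among the compounds shown, and "the series" means these compounds.

Compound 1 `C=C[C@](C)(CCCC(C)C)CCc1ccc(O)cc1`: 27500 nM
Compound 2 `COc1ccc(/C=C/[C@@](C)(/C=C/c2ccc(O)c(/C=C/C(C)=O)c2)CCC=C(C)C)cc1`: > 43400 nM
Compound 3 `CC(C)=CCC[C@@](C)(/C=C/c1ccccc1)/C=C/c1ccc(O)cc1`: > 43400 nM

All three compounds were tested in a functional assay on NALM-6 cells (Homo sapiens) for cytotoxicity, with a stated time of 72 h; a higher number here means that more compound is needed for the effect, a lower number that less compound is needed. Compound 1 gives a true number, 27500 nM. For compound 2, > 43400 nM is a limit of the assay and not a number. For compound 3, > 43400 nM is likewise a limit. As far as these compounds go, compound 3 therefore stands with compound 2 at the limit of > 43400 nM in this assay, at which 2 of the 3 values shown sit, and its exact value is unknown.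

Compound 4 `CC(C)=CCC[C@](C)(/C=C/c1ccc(O)cc1)/C=C/c1cccc(Cl)c1` differs from compound 3 in one place: chloro in place of hydrogen on an aromatic carbon. In words, chloro replaces hydrogen on an aromatic carbon, turning phenyl into 3-chlorophenyl. Going by the values given here, no measured pair here shows what this swap does in this assay. Only a small step towards less compound needed is expected, and it may not exceed the scatter. The estimated change an at least 1.4-fold lower number from compound 3 to compound 4 (0.16 log units; that floor lies within the scatter) is therefore modest and uncertain. Compound 4 is expected at about 30000 nM, within an estimated range of 14000 nM to 43400 nM.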

Compound 4, half-maximal effective concentration: > 43400 nM
Compound 4 gave a limit, no number (the forecaster's own chance of this, stated with the estimate: 45%); middle value at least 1.4-fold (0.16 log units) away from the limit.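

Compound 3 and compound 4 each give only a limit and not a number in this assay, so no step between them can be read: the limit of > 43400 nM in this assay, at which 3 of the 4 values shown sit.

As far as these compounds go, whether turning phenyl into 3-chlorophenyl changes the amount of compound needed, and in which direction, stays open.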